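Amide aryl variation and cytotoxicity in the chromone series

A few compounds are considered here, and "the series" means these few. Any claim that something is new, unique, unknown or untested is made for them only; others in the source may bear on it.

The three measured compounds share one core and differ only in the aryl group on the amide-type nitrogen. In an ADME assay on HepG2 2.2.15 cells (Homo sapiens) for cytotoxicity, read by MTT assay, with stated times of 48 h and 9 days (on this read-out higher numbers stand for lower toxicity in this test and lower numbers for higher toxicity in this test), compound 1 `COc1ccc2c(=O)c(/C=C/C(=O)Nc3ccccc3Cl)coc2c1` gives 1010000 nM, compound 2 `COc1cccc(NC(=O)/C=C/c2coc3cc(OC)ccc3c2=O)c1` gives 1130000 nM, and compound 3 `COc1ccc(NC(=O)/C=C/c2coc3cc(OC)ccc3c2=O)cc1` gives 718000 nM. Compound 3 sits within the scatter of both neighbours: a 1.4-fold lower number from compound 1 to compound 3 (0.15 log units; within the scatter) and a 1.6-fold lower number from compound 2 to compound 3 (0.20 log units; within the scatter). The step of a 1.1-fold higher number from compound 1 to compound 2 (0.05 log units; within the scatter) is likewise within the scatter, so none of the three aryl swaps has moved this read-out.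

Compound 4 `COc1ccc2c(=O)c(/C=C/C(=O)Nc3ccc(C)cc3)coc2c1` continues the same kind of change on the same ring: methyl in place of methoxy on an aromatic carbon. All three measured steps bear on it, each an exchange of one small aryl substituent for another, and each within the scatter. The expectation is therefore that a 1.1-fold higher number from compound 3 to compound 4 (0.05 log units; within the scatter) in this assay stays within the scatter, with no direction favoured. Compound 4 is estimated at 800000 nM, in a range from 400000 nM to 1600000 nM.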

Compound 4, half-maximal cytotoxic concentration: 979000 nM
Estimate against measurement, compound 4: 1.2-fold (0.09 log units) below; measured number inside the range.
By their numbers in this assay, from the lowest: compounds 3, 4, 1 and 2 (each within the scatter of the next).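

In this assay, methyl in place of methoxy on an aromatic carbon para to a large group gives a 1.4-fold higher number from compound 3 to compound 4 (0.13 log units; within the scatter), so removing the methoxy oxygen at this position leaves the read-out unresolved from the parent 4-methoxyphenyl compound. The 4-methylphenyl group also stays level with the other two aryl groups, with a 1.2-fold lower number from compound 2 to compound 4 (0.06 log units; within the scatter) and a 1.0-fold lower number from compound 1 to compound 4 (0.01 log units; within the scatter) as the steps, so all four compounds now sit within the scatter of one another, whether the aryl substituent is a methoxy, a chlorine or a methyl. Nothing available here accounts for this flatness.

Still open, on these data alone, is whether an amine or a carboxylic acid at this position would give a step beyond the scatter. A longer chain in place of the methyl also remains untested among the compounds shown, as does any change to the shared core.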